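The compounds below may be only part of what the source reports. "The series", "measured", "known", "first", "only" and "open" are said of these compounds alone.

In a functional assay on a cell-free system (plasma) for inhibition of Thromboxane-A synthase (Homo sapiens) (a higher number here means a weaker inhibitor, a lower number a stronger inhibitor), compound 2 `COc1ccc(COCC(Cn2ccnc2)OCCCCCCC(=O)O)cc1` gives 1890 nM. Among the three measured compounds, compound 2 stands second highest: compound 1 `COc1ccc(COCC(Cn2ccnc2)OCCCCCC(=O)O)cc1` gives 560 nM, and compound 3 `CCOC(=O)C(C)(C)CCCCOC(COCc1ccc(OC)cc1)Cn1ccnc1` gives 17600 nM. The step of a 3.4-fold higher number from compound 1 to compound 2 (0.53 log units; beyond the scatter) and the steps of a 31-fold higher number from compound 1 to compound 3 (1.50 log units; beyond the scatter) and a 9.3-fold higher number from compound 2 to compound 3 (0.97 log units; beyond the scatter) show that every change to the acid end of the chain so far has weakened inhibition.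

Compound 4 `COc1ccc(COCC(Cn2ccnc2)OCCCCCCC(C)(C)C(=O)O)cc1` differs from compound 2 in one place: 1-carboxy-1-methylethyl in place of carboxy on a saturated chain carbon, six bonds along the chain from an oxygen on a saturated carbon. The step from compound 2 to compound 3 bears most directly on this, since it also introduces two methyl groups on the carbon carrying the acid group, but it carries an ethyl ester as well, so the two effects cannot be separated. The step from compound 1 to compound 2 shows that lengthening the chain by one carbon weakened inhibition. Both point the same way, so for compound 4 a weakening is expected, of the size a 2.6-fold higher number from compound 2 to compound 4 (0.42 log units; beyond the scatter). Compound 4 is therefore estimated at 5000 nM, with a range from 1500 nM to 17000 nM.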

Compound 4, half-maximal inhibitory concentration: > 20000 nM
Compound 4: a limit, no number; the forecaster's own chance of this, stated with the estimate: 5%; middle value at least 4.0-fold (0.60 log units) from the limit.
By their numbers in this assay, from the lowest: compound 1; then compound 2; then compound 3. At a limit, above all of these: compound 4.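

In this assay, compound 4 gives a limit and not a number: the limit of > 20000 nM in this assay, at which 1 of the 4 values shown sits. The steps of an at least 10-fold higher number from compound 2 to compound 4 (1.02 log units; beyond the scatter) and an at least 35-fold higher number from compound 1 to compound 4 (1.55 log units; beyond the scatter) are both large, so a heavy loss of inhibition occurs here with the acid still free, whereas in compound 3 the two methyl groups came together with an ethyl ester. The step of an at least 1.1-fold higher number from compound 3 to compound 4 (0.05 log units; that floor lies within the scatter) has a floor within the scatter, so it gives no firm order for this pair.

The compounds shown do not separate the effect of the two methyl groups from that of the added chain length in compound 4. Still open, from the compounds shown here alone, is how a shorter chain carrying the same two methyl groups, or a single methyl group on the carbon bearing the carboxylic acid, would read.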